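The compounds below may be only part of what the source reports. "The series", "measured", "known", "first", "only" and "open" are said of these compounds alone.

Measured in a functional assay on Jurkat cells (Homo sapiens) for antiproliferative activity, read by MTT assay; a lower number here means a stronger inhibitor, a higher number a weaker inhibitor:
compound 1 `COc1cc2c(cc1OC)C(=O)/C(=C/c1cccc(C)c1)C2`: 1800 nM
compound 2 `COc1cc2c(cc1OC)C(=O)/C(=C/c1cccc([N+](=O)[O-])c1)C2`: 22000 nM
compound 3 `COc1cc2c(cc1OC)C(=O)/C(=C/c1cc([N+](=O)[O-])ccc1O)C2`: 14500 nM

Compound 1 and compound 2 differ in one place, (methyl in place of nitro on an aromatic carbon), with a 12-fold higher number from compound 1 to compound 2 (1.09 log units; beyond the scatter). Compound 2 and compound 3 differ by hydroxy in place of hydrogen on an aromatic carbon, which gave a 1.5-fold lower number from compound 2 to compound 3 (0.18 log units; within the scatter). Compound 4 `COc1cc2c(cc1OC)C(=O)/C(=C/c1ccc(O)c(C)c1)C2` is not yet measured; it differs from compound 1 by hydroxy in place of hydrogen on an aromatic carbon. This is the same kind of change as from compound 2 to compound 3, not the same one: there the entering hydroxy sits ortho to a large group and para to a nitro group (3 heavy atoms), here ortho to a methyl group (1 heavy atom) and para to a large group. Among the measured compounds shown here, only this single measured example of the change is known, and it sits on the core carrying nitro rather than methyl. For compound 4 in this assay a step of about a 1.2-fold lower number from compound 1 to compound 4 (0.08 log units; within the scatter) is expected, resting on a 1.5-fold lower number from compound 2 to compound 3 (0.18 log units; within the scatter). Compound 4 is therefore estimated at 1500 nM, between 600 nM and 4000 nM.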

Compound 4, half-maximal inhibitory concentration: 1160 nM
Estimate against measurement, compound 4: 1.3-fold (0.11 log units) above, within the range that was stated.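

In this assay, hydroxy in place of hydrogen on the core of compound 1 gives a 1.6-fold lower number from compound 1 to compound 4 (0.19 log units; within the scatter). On the core carrying nitro, the same change gives a step of matching size: the same change on two cores in this assay, a 1.5-fold lower number (0.18 log units; within the scatter) from compound 2 to compound 3 and a 1.6-fold lower number (0.19 log units; within the scatter) from compound 1 to compound 4, 1.0-fold (0.01 log units) apart, within the scatter of two such steps

So on these two cores the change carries over with no step beyond the scatter, but two examples, with the hydroxy placed differently on the ring in each, establish no general rule for other cores.

Still open, as far as these compounds go, is whether an amine or a carboxylic acid in place of the hydroxy would give a step beyond the scatter. Also open, from the compounds shown here alone, is how the hydroxy change behaves on a core carrying a halogen such as chlorine instead of methyl or nitro.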